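Urea Variation in a Kinase Inhibitor Series

A few compounds are considered here, and "the series" means these few. Any claim that something is new, unique, unknown or untested is made for them only; others in the source may bear on it.

Measured in an assay on isolated protein for inhibition of proto-oncogene tyrosine-protein kinase receptor Ret variant V804L (Homo sapiens), read by 33P incorporation, with stated times of 15 min and 40 min; a lower number here means a stronger inhibitor, a higher number a weaker inhibitor:
compound 1 `O=C(Nc1ccc(Nc2ncnc3c2OCCN3)cc1)Nc1ccc(C(F)(F)F)cc1`: 2470 nM
compound 2 `Cc1cc(C)cc(NC(=O)Nc2ccc(Nc3ncnc4c3OCCN4)cc2)c1`: 3770 nM
compound 3 `O=C(Nc1ccc(Nc2ncnc3c2OCCN3)cc1)Nc1cc(Cl)cc(Cl)c1`: 4480 nM

Compound 3 gives the highest of the three numbers, yet the steps of a 1.8-fold higher number from compound 1 to compound 3 (0.26 log units; within the scatter) and a 1.2-fold higher number from compound 2 to compound 3 (0.07 log units; within the scatter) both lie within the scatter, as does a 1.5-fold higher number from compound 1 to compound 2 (0.18 log units; within the scatter); the three compounds are not separated by this assay. Compound 4 `CC(C)(C)c1csc(NC(=O)Nc2ccc(Nc3ncnc4c3OCCN4)cc2)n1` carries the change (4-(tert-butyl)-1,3-thiazol-2-yl in place of 3,5-dichlorophenyl on an amide-type nitrogen). Going by the values given here, no measured step bears directly on it: each of the three steps exchanges one substituted phenyl for another, and none alters the ring itself. Those steps were all small, so for compound 4 no step beyond the scatter is expected, though the uncertainty is wider than for the phenyl swaps. Compound 4 is therefore estimated at 3000 nM, within 700 nM to 13000 nM, an expected step of a 1.5-fold lower number from compound 3 to compound 4 (0.17 log units; within the scatter).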

Compound 4, half-maximal inhibitory concentration: > 10000 nM
Compound 4 was reported as a limit (the forecaster's own chance of this, stated with the estimate: 5%); middle value at least 3.3-fold (0.52 log units) away from the limit.
By their numbers in this assay, from the lowest: compounds 1, 2 and 3 (each within the scatter of the next). At a limit, above all of these: compound 4.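

In this assay compound 4 is reported only as a limit, > 10000 nM. Going by these compounds alone, putting 4-(tert-butyl)-1,3-thiazol-2-yl on the amide-type nitrogen gives the first steps beyond the scatter in this set: an at least 2.2-fold higher number from compound 3 to compound 4 (0.34 log units; beyond the scatter), an at least 2.6-fold higher number from compound 2 to compound 4 (0.42 log units; beyond the scatter) and an at least 4.0-fold higher number from compound 1 to compound 4 (0.60 log units; beyond the scatter). The position showed no separation across the phenyl swaps among compound 1, compound 2 and compound 3, but it does respond to this change of ring, with the size of the step bounded only by the limit: the limit of > 10000 nM in this assay, at which 1 of the 4 values shown sits.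

The ring and the tert-butyl group changed together in compound 4, so the compounds shown leave open which of them matters. A plain 1,3-thiazol-2-yl or a 4-(tert-butyl)phenyl group on the same nitrogen would separate the two.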